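Notes: from compound 2 to compound 4

The compounds below may be only part of what the source reports. "The series", "measured", "known", "first", "only" and "open" are said of these compounds alone.

Measured in an ADME assay on HepG2 cells (Homo sapiens) for cytotoxicity, read by MTT assay, with a stated time of 7 days; on this read-out higher numbers stand for weaker inhibition and lower numbers for stronger inhibition:
- compound 1 `COc1ccc(C2CC(c3ccc(O)cc3)=NN2C(=O)c2cccnc2)cc1OC`: 53600 nM
- compound 2 `COc1ccc(OC)c(C2CC(c3ccc(O)cc3)=NN2C(=O)c2cccnc2)c1`: 56800 nM
- compound 3 `O=C(c1cccnc1)N1N=C(c2ccc(O)cc2)CC1c1ccc([N+](=O)[O-])cc1`: 18600 nM

Compound 2, at 56800 nM, sits level with compound 1 and above compound 3. The two dimethoxyphenyl compounds do not separate, with a 1.1-fold higher number from compound 1 to compound 2 (0.03 log units; within the scatter).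

The next structure is compound 4 `O=C(c1cccnc1)N1N=C(c2ccc(O)cc2)CC1c1ccc(Br)cc1`, where 4-bromophenyl takes the place of 2,5-dimethoxyphenyl on a saturated ring carbon: 4-bromophenyl in place of 2,5-dimethoxyphenyl on a saturated ring carbon.

The closest guide is compound 3, which carries 4-nitrophenyl at the same place, with a 3.1-fold lower number from compound 2 to compound 3 (0.48 log units; beyond the scatter). The matching change from the other dimethoxyphenyl compound is of similar size, with a 2.9-fold lower number from compound 1 to compound 3 (0.46 log units; beyond the scatter). Both steps are modest and point the same way. Among the measured compounds shown here, still, they rest on one replacement group only, and no measured compound carries 4-bromophenyl. For the measured compounds named here, a modest move towards a lower number in this assay is therefore expected, possibly smaller than the one seen for compound 3, and it may not clear the scatter.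

The expected step is a 2.2-fold lower number from compound 2 to compound 4 (0.34 log units; beyond the scatter).

For compound 4 the estimated value is 26000 nM, with an expected range from 11000 nM to 60000 nM.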

Compound 4, half-maximal inhibitory concentration: 58700 nM
Compound 4: middle estimate off by 2.3-fold (0.35 log units), on the low side; the measured number falls inside the stated range.
By their numbers in this assay, from the lowest: compound 3; then compounds 1, 2 and 4 (each within the scatter of the next).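

In this assay, 4-bromophenyl on the saturated ring carbon does not separate from either dimethoxyphenyl group, with a 1.0-fold higher number from compound 2 to compound 4 (0.01 log units; within the scatter) and a 1.1-fold higher number from compound 1 to compound 4 (0.04 log units; within the scatter), so among these compounds, replacing two methoxy groups with a single bromo substituent leaves the number unmoved. The step between the two 4-substituted phenyl groups is what sets compound 3 apart: bromo in place of nitro on an aromatic carbon gives a 3.2-fold higher number from compound 3 to compound 4 (0.50 log units; beyond the scatter), so the lower number seen so far goes with 4-nitrophenyl alone and not with 4-substitution as such. Nothing available on these compounds explains the gap between the nitro and bromo compounds.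

On these data alone, whether an amine or a carboxylic acid at the 4-position of that phenyl ring would fall with compound 3 or with the other three compounds remains open, as does the outcome of a longer alkyl chain in place of the aryl group. As far as these compounds go, the 4-hydroxyphenyl and (pyridin-3-yl)carbonyl groups are the same in all four compounds, so how far this pattern holds when either of them is changed is also open.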